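The source may hold more compounds than are shown below. What is called first, only, known or untested is meant among the compounds shown, and "the series" means these compounds.

Series notes. Compound 1 `COc1cc2c(Oc3ccc(NC(=O)c4cn(-c5cc(C)ccc5C)cn4)cc3F)ccnc2cc1OCCCN1CCN(C)CC1` gives 350 nM in a functional assay on A549 cells (Homo sapiens) for cytotoxicity, read by MTT assay, with a stated time of 72 h; on this read-out lower numbers stand for stronger inhibition and higher numbers for weaker inhibition. Compound 2 `COc1cc2c(Oc3ccc(NC(=O)c4cn(-c5cc(C)ccc5C)cn4)cc3F)ccnc2cc1OCCCN1CCC(C)CC1` carries one change against compound 1, (4-methylpiperidin-1-yl in place of 4-methylpiperazin-1-yl on a saturated chain carbon, three bonds along the chain from an oxygen on an aromatic ring), and in this assay compound 2 gives 7420 nM; the step is a 21-fold higher number from compound 1 to compound 2 (1.33 log units; beyond the scatter). Compound 3 `COc1cc2c(Oc3ccc(NC(=O)/C=C/S(=O)(=O)c4ccccc4F)cc3F)ccnc2cc1OCCCN1CCN(C)CC1` differs from compound 1 in the core, and that difference is not broken down here; in this assay compound 3 gives 150 nM, the lowest number of the three measured. Compound 4 `COc1cc2c(Oc3ccc(NC(=O)/C=C/S(=O)(=O)c4ccccc4F)cc3F)ccnc2cc1OCCCN1CCC(C)CC1` is not yet measured and stands to compound 3 as compound 2 stands to compound 1: 4-methylpiperidin-1-yl in place of 4-methylpiperazin-1-yl on a saturated chain carbon, three bonds along the chain from an oxygen on an aromatic ring. Going by the values given here, the change is the same in both pairs, at the same place, so a step of like size is expected, a 20-fold higher number from compound 3 to compound 4 (1.30 log units; beyond the scatter), because the single precedent is a 21-fold higher number from compound 1 to compound 2 (1.33 log units; beyond the scatter). Compound 4 is accordingly expected near 3000 nM, most likely between 800 nM and 12000 nM.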

Compound 4, half-maximal inhibitory concentration: 410 nM
For compound 4 the middle estimate is 7.3-fold (0.86 log units) above the measured one; the measured number lies below the stated range.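

In this assay, 4-methylpiperidin-1-yl in place of 4-methylpiperazin-1-yl gives a 2.7-fold higher number from compound 3 to compound 4 (0.44 log units; beyond the scatter), so the number rises on both cores, but the size of the step does not carry over from one core to the other: the same change on two cores in this assay, a 21-fold higher number (1.33 log units; beyond the scatter) from compound 1 to compound 2 and a 2.7-fold higher number (0.44 log units; beyond the scatter) from compound 3 to compound 4, 7.8-fold (0.89 log units) apart, beyond the scatter of two such steps

A step measured on one core is therefore a poor guide to its size on the other, at least for these two pairs. The pairs do not show which part of the core difference sets the gap, and two pairs establish no general rule for the series.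

Still open, going by these compounds, is how a morpholin-4-yl group would behave at the same place on each core. Also open, on these data alone, is whether a butyl chain in place of the propyl chain would widen or narrow the gap.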